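Aromatic amide swapped for a methylpyrazole carboxamide

This account rests on a few compounds, and the source may have more. Where it says the series, first, only, none or still open, it means among the compounds named here.

Compounds measured so far:
compound 1, `CC1(C)Cc2c(sc(NC(=O)c3ccccc3O)c2C(N)=O)C(C)(C)O1`: 4 nM
compound 2, `CC1(C)Cc2c(sc(NC(=O)C(C)(C)CO)c2C(N)=O)C(C)(C)O1`: 75 nM

Both compounds were tested in an assay on cells for positive allosteric modulation of Cystic fibrosis transmembrane conductance regulator variant F508del (Homo sapiens), with stated times of 10 min and 7 s, in the presence of a further agent that is not named here; a higher number here means that more compound is needed for the effect, a lower number that less compound is needed. For the measured compounds named here, compound 1 gives the lowest of the two numbers, and the only measured step, a 19-fold higher number from compound 1 to compound 2 (1.27 log units; beyond the scatter), shows what happens when the aromatic 2-hydroxyphenyl on the carbonyl carbon is exchanged for an open-chain 1-(hydroxymethyl)-1-methylethyl.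

Compound 3, `Cc1cn[nH]c1C(=O)Nc1sc2c(c1C(N)=O)CC(C)(C)OC2(C)C`, has not been measured. Its change from compound 1 is 4-methyl-1H-pyrazol-5-yl in place of 2-hydroxyphenyl on a carbonyl carbon. Unlike the step to compound 2, this change keeps an aromatic ring on the carbonyl carbon and keeps one hydrogen-bond donor and one hydrogen-bond acceptor there. The step from compound 1 to compound 2 is the only one that bears on it, and it is large, but it replaces the ring with a chain, which compound 3 does not do. A smaller shift is therefore expected, toward a higher number but possibly within the scatter, as the estimated step of a 2.5-fold higher number from compound 1 to compound 3 (0.40 log units; beyond the scatter) expresses. For compound 3 the expected value in this assay is 10 nM, within a range from 3 nM to 40 nM.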

Compound 3, half-maximal effective concentration: 2 nM
Estimate against measurement, compound 3: 5.0-fold (0.70 log units) above; the measured number lies below the stated range.
By their numbers in this assay, from the lowest: compounds 3 and 1 (each within the scatter of the next); then compound 2.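

At this place on a carbonyl carbon whose other neighbour is an amide-type nitrogen, exchanging 2-hydroxyphenyl for 4-methyl-1H-pyrazol-5-yl gives in this assay a result that cannot be told apart from the starting point: a 2.0-fold lower number from compound 1 to compound 3 (0.30 log units; within the scatter) is the step, so neither the six-membered aromatic ring of carbon only nor its oxygen is needed for a number in this low range. The large gap to the open-chain group now appears against a second aromatic ring as well, as a 38-fold lower number from compound 2 to compound 3 (1.57 log units; beyond the scatter) shows, so it is not tied to 2-hydroxyphenyl alone. Across these three compounds, the two with an aromatic ring on the carbonyl carbon lie close together and the one with 1-(hydroxymethyl)-1-methylethyl lies well apart, and none of the three goes against this.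

What the compounds shown leave open is how a pyrazole ring without the methyl group, a pyridine ring or an amine-bearing chain would read at this place in this assay and whether the pyrazole ring hydrogen on nitrogen takes part in the result. Nothing given here offers an explanation for the result.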